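This account rests on a few compounds, and the source may have more. Where it says the series, first, only, none or still open, it means among the compounds named here.

Compound 1 `COc1ccc2nc(C)cc(OCC(=O)Nc3cc(C)cc(C)c3)c2c1` and compound 2 `COc1ccc2nc(C)cc(OCC(=O)Nc3ccc(F)cc3)c2c1` share one core and differ only in the group on the amide-type nitrogen. In a physicochemical assay for lipophilicity, read by HPLC, in phosphate buffer, measured as chromatographic lipophilicity, at pH 7.4 (on this read-out higher numbers stand for higher lipophilicity and lower numbers for lower lipophilicity), compound 1 gives 5.64 and compound 2 gives 4.49. Within the data shown here, compound 2 therefore holds the lower of the two numbers, and the only measured step, a number 1.15 log units lower from compound 1 to compound 2 (beyond the scatter), belongs to the exchange of 3,5-dimethylphenyl for 4-fluorophenyl on that nitrogen.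

Compound 3 `COc1ccc2nc(C)cc(OCC(=O)NNC(=O)c3ccncc3)c2c1` has not yet been run in this assay. It differs from compound 2 in one place: ((pyridin-4-yl)carbonyl)amino in place of 4-fluorophenyl on an amide-type nitrogen. Among the measured compounds shown here, the one measured step bears on this only loosely, since it also sits on the amide-type nitrogen, yet it swapped one six-membered aromatic ring of carbon only for another and still shifted this assay by more than the scatter. The present change goes further, removing the ring of carbon only and bringing in a six-membered aromatic ring with a hetero atom through a ((pyridin-4-yl)carbonyl)amino link, so a downward step well beyond the scatter is expected. The expected step is therefore estimated as a number 1.99 log units lower from compound 2 to compound 3 (beyond the scatter). Compound 3 is accordingly estimated at 2.5, with a range from 1.8 to 3.3.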

Compound 3, distribution coefficient: 1.48
Compound 3: middle estimate off by 1.02 log units, on the high side, and the stated range ends above it.
By their numbers in this assay, from the lowest: compound 3; then compound 2; then compound 1.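

At the amide-type nitrogen, the exchange of an all-carbon aromatic ring for a link-bearing group moves this assay much further than the exchange between the two carbon-only rings: a number 3.01 log units lower from compound 2 to compound 3 (beyond the scatter) stands against a number 1.15 log units lower from compound 1 to compound 2 (beyond the scatter) as the earlier step at this place. Measured against the other aryl group, the same entering group gives a number 4.16 log units lower from compound 1 to compound 3 (beyond the scatter) and places ((pyridin-4-yl)carbonyl)amino at the low end of the three groups, so this single position carries a wide span of the read-out while the shared core stays unchanged. The entering group differs at once in its ring with a hetero atom, its double bond outside aromatic rings and its hydrogen-bond donor and acceptors, and no supporting data assign the size of the step to any one of these features.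

The compounds shown do not separate the contribution of the ring from that of the linking carbonyl and amino unit, and a benzoylamino group on the same nitrogen would make that division readable. Nor do they show where an aliphatic amine or a carboxylic acid on this nitrogen's substituent would fall in the order of the three groups.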